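Replacing the Sulfamoylamino Group on Compound 3 with Hydroxy

The compounds below may be only part of what the source reports. "The series", "measured", "known", "first", "only" and "open" are said of these compounds alone.

Of the compounds shown here, three sharing one core have been measured in an assay on CHO cells for displacement of a labelled ligand from transient receptor potential cation channel subfamily V member 1 (Homo sapiens), read by scintillation counting, with a stated time of 60 min; a lower number here means a stronger inhibitor, a higher number a weaker inhibitor. Compound 1 `CN(C)C1(Cc2ccccc2)CCN(c2cc(C(F)(F)F)ccc2CNC(=O)Nc2ccc(NS(C)(=O)=O)c(F)c2)CC1` gives 1160 nM. Compound 2 `CN(C)C1(Cc2ccccc2)CCN(c2cc(C(F)(F)F)ccc2CNC(=O)Nc2ccc(CNS(C)(=O)=O)c(F)c2)CC1` gives 16.4 nM. Compound 3 `CN(C)C1(Cc2ccccc2)CCN(c2cc(C(F)(F)F)ccc2CNC(=O)Nc2ccc(CNS(N)(=O)=O)c(F)c2)CC1` gives 15.3 nM, the lowest number of the three, though its gap to compound 2 lies within the scatter, so those two cannot be ranked against each other. The two large steps are a 71-fold lower number from compound 1 to compound 2 (1.85 log units; beyond the scatter) and a 76-fold lower number from compound 1 to compound 3 (1.88 log units; beyond the scatter); the small one is a 1.1-fold lower number from compound 2 to compound 3 (0.03 log units; within the scatter).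

Compound 4 `CN(C)C1(Cc2ccccc2)CCN(c2cc(C(F)(F)F)ccc2CNC(=O)Nc2ccc(CO)c(F)c2)CC1` differs from compound 3 in one place: hydroxy in place of sulfamoylamino on a saturated chain carbon bound to an aromatic carbon. For the measured compounds named here, none of the measured steps removes the sulfonyl group altogether; the one step that touches it, a 1.1-fold lower number from compound 2 to compound 3 (0.03 log units; within the scatter), swaps only a substituent on the sulfonyl sulfur and stays within the scatter. The large steps show that where this group sits matters a great deal, but not what happens when it is gone. Going by the values given here, with no direct precedent, the expectation in this assay is a higher number, meaning a weaker inhibitor, by a moderate margin and with wide uncertainty: the step from compound 3 to compound 4 is estimated as a 9.8-fold higher number from compound 3 to compound 4 (0.99 log units; beyond the scatter). For compound 4 the estimated value is 150 nM, with a range from 30 nM to 700 nM.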

Compound 4, inhibition constant: 27.9 nM
Beside the measured number, compound 4's estimate is 5.4-fold (0.73 log units) above it; measured number below the stated range.
By their numbers in this assay, from the lowest: compounds 3, 2 and 4 (each within the scatter of the next); then compound 1.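

In this assay, a sulfonyl group on the chain carbon is not required for a number in this range: both a 1.8-fold higher number from compound 3 to compound 4 (0.26 log units; within the scatter) and a 1.7-fold higher number from compound 2 to compound 4 (0.23 log units; within the scatter) stay within the scatter, even though hydroxy, with 1 heavy atom, takes the place of sulfamoylamino, with 5 heavy atoms. The large gap to compound 1 also survives without any sulfonyl group, as a 42-fold lower number from compound 1 to compound 4 (1.62 log units; beyond the scatter) shows for hydroxymethyl in place of methanesulfonamido on an aromatic carbon, so compounds 2, 3 and 4 all sit far from compound 1 whichever of the three groups they carry. No supporting evidence is available to explain why these three groups give such similar numbers.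

The compounds shown leave open whether the hydroxy contributes at all, which a plain methyl group on the aromatic carbon, carrying no oxygen, could help to separate from the effect of the chain carbon alone. They also leave open how far this tolerance extends, for example to an amine or a carboxylic acid at the same place, or to a longer chain ending in hydroxy.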